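Swapping the Aryl Group on the Benzamide Carbonyl

This account rests on a few compounds, and the source may have more. Where it says the series, first, only, none or still open, it means among the compounds named here.

The three measured compounds share one core and differ only in the aromatic group attached to a carbonyl carbon. In an assay on isolated protein for inhibition of Rho-associated protein kinase 1 (Homo sapiens), read by scintillation counting, radiometric assay and 33P incorporation, with a stated time of 40 min, in the presence of a further agent that is not named here (a lower number here means a stronger inhibitor, a higher number a weaker inhibitor), compound 1 `CC(C)(C)c1ccc(C(=O)Nc2cccc(NC(=O)COc3ccc4c(=O)ccoc4c3)c2)cc1` gives 165 nM, compound 2 `COc1ccc(C(=O)Nc2cccc(NC(=O)COc3ccc4c(=O)ccoc4c3)c2)cc1` gives 18 nM, and compound 3 `Cc1cc(C(=O)Nc2cccc(NC(=O)COc3ccc4c(=O)ccoc4c3)c2)ccc1C(F)(F)F` gives 460 nM, the highest of the three numbers. The step of a 9.2-fold lower number from compound 1 to compound 2 (0.96 log units; beyond the scatter) shows how much a small change on that aryl ring can move the result, and the step of a 26-fold higher number from compound 2 to compound 3 (1.41 log units; beyond the scatter) is larger still, while a 2.8-fold higher number from compound 1 to compound 3 (0.45 log units; beyond the scatter) is more modest.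

Compound 4 `Nc1ccc(C(=O)Nc2cccc(NC(=O)COc3ccc4c(=O)ccoc4c3)c2)cc1` takes this further: a group of 7 heavy atoms (6 carbon, 1 nitrogen; one six-membered aromatic ring of carbon only) in place of a group of 11 heavy atoms (8 carbon, 3 fluorine; one six-membered aromatic ring of carbon only), on a carbonyl carbon. The group that enters brings one hydrogen-bond donor and one acceptor, as the methoxy group of compound 2 brought an acceptor. Both steps that lead to compound 3, a 2.8-fold higher number from compound 1 to compound 3 (0.45 log units; beyond the scatter) and a 26-fold higher number from compound 2 to compound 3 (1.41 log units; beyond the scatter), point the same way, so a lower number is expected for compound 4, estimated as a 13-fold lower number from compound 3 to compound 4 (1.12 log units; beyond the scatter) in this assay. The expected value for compound 4 is 35 nM, with a range from 8 nM to 150 nM.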

Compound 4, half-maximal inhibitory concentration: 802 nM
Estimate against measurement, compound 4: 23-fold (1.36 log units) below; measured number above the stated range.
By their numbers in this assay, from the lowest: compound 2; then compound 1; then compounds 3 and 4 (each within the scatter of the next).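

Amino in place of methoxy on an aromatic carbon gives a 45-fold higher number from compound 2 to compound 4 (1.65 log units; beyond the scatter) and is the largest step in this set, so the low number of compound 2 does not carry over to every small group that brings a hydrogen-bond acceptor. Amino in place of tert-butyl gives a 4.9-fold higher number from compound 1 to compound 4 (0.69 log units; beyond the scatter) in the same direction, while the step of a 1.7-fold higher number from compound 3 to compound 4 (0.24 log units; within the scatter) means that the 4-aminophenyl group and the larger fluorine-bearing group cannot be told apart here, even though only the first has a hydrogen-bond donor and acceptor. No measurement at hand explains why amino and methoxy part so widely.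

On these data alone, whether the result depends on the oxygen of the methoxy group or on its methyl stays open, and a hydroxy or an ethoxy group could separate these. A dimethylamino group would likewise test whether the hydrogens on the amino nitrogen matter.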